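Methoxy for methyl: working notes on compound 3

The source may report more compounds than this note shows. Statements on the series, on what has been measured and on what is new or still open speak of the compounds shown alone.

In a functional assay on T47D cells (Homo sapiens) for antiproliferative activity, read by MTT assay (a lower number here means a stronger inhibitor, a higher number a weaker inhibitor), compound 1 (`O=C1Nc2ccc(Br)cc2/C1=N/NC(=O)c1cc2cc(Br)ccc2o1`) gives 3820 nM and compound 2 (`Cc1ccc2c(c1)/C(=N/NC(=O)c1cc3cc(Br)ccc3o1)C(=O)N2`) gives 4530 nM and these two values lie within the scatter of each other. For the measured compounds named here, compound 2 therefore cannot be told apart from compound 1 on the numbers so far.

Compound 3 (`COc1ccc2c(c1)/C(=N/NC(=O)c1cc3cc(Br)ccc3o1)C(=O)N2`) keeps the rest of compound 2 and carries methoxy in place of methyl on an aromatic carbon.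

Going by the values given here, only one measured step bears on this change (a 1.2-fold higher number from compound 1 to compound 2 (0.07 log units; within the scatter)). It is the replacement of bromo by methyl on the same aromatic carbon, and it stays within the scatter. Among the compounds with values here, one step across two groups is thin evidence, and no measured compound yet carries methoxy. No step beyond the scatter is expected in this assay and no direction is favoured. The estimate used here is an expected 1.0-fold lower number from compound 2 to compound 3 (0.01 log units; within the scatter) and no more. For compound 3 the estimated value is 4400 nM (expected range 2100 nM to 9000 nM).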

Compound 3, half-maximal inhibitory concentration: 7800 nM
Compound 3: middle estimate off by 1.8-fold (0.25 log units), on the low side; the measured number falls inside the stated range.
By their numbers in this assay, from the lowest: compounds 1, 2 and 3 (each within the scatter of the next, the first and the last beyond it).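

In this assay the exchange of methyl for methoxy on this aromatic carbon gives a 1.7-fold higher number from compound 2 to compound 3 (0.24 log units; within the scatter) and so cannot be told apart from no change, even though the entering group adds a heavy atom and a hydrogen-bond acceptor. For the compounds shown here, the position does yield something the first pair could not: the exchange of bromo for methoxy on the same carbon gives a 2.0-fold higher number from compound 1 to compound 3 (0.31 log units; beyond the scatter) and is the only step among the three compounds printed beyond the scatter, though it is modest and sits close to that limit. Nothing available on these compounds accounts for this step, so the reading stays purely numerical.

Bromo, methyl and methoxy span only a narrow range of values at this carbon, and the compounds shown leave open whether an amine, a hydroxy group or a carboxylic acid here would stay in that range or leave it. On these data alone, all three compounds also share the rest of the structure, so it remains open whether the step from bromo to methoxy would hold with a group other than bromo on the far side of the molecule.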